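The source may hold more compounds than are shown below. What is called first, only, known or untested is meant among the compounds shown, and "the series" means these compounds.

Measured compounds:
- compound 1, `N=C(NCCCc1c[nH]cn1)NC(=O)CC(c1ccccc1)c1ccccc1`, which in a functional assay on cardiac atrium for agonist activity at histamine H2 receptor (Cavia porcellus) (a higher number here means that more compound is needed for the effect, a lower number that less compound is needed), gives 28.2 nM
- compound 2, `N=C(NCCCc1c[nH]cn1)NC(=O)CC(c1ccccc1)c1ccc(F)c(F)c1`, which in this assay gives 53.7 nM
- compound 3, `N=C(NCCCc1c[nH]cn1)NC(=O)CC(c1ccccc1)c1ccccn1`, which in this assay gives 51.3 nM

Compound 2 has the highest of the three numbers, but its nearest neighbour compound 3 and its furthest neighbour compound 1 both sit within the scatter of it, so the three compounds cannot be told apart on these data. Compound 4, `N=C(NCCCc1c[nH]cn1)NC(=O)CC(c1ccc(F)c(F)c1)c1nccn1Cc1ccccc1`, differs from compound 2 in one place: 1-benzyl-1H-imidazol-2-yl in place of phenyl on a saturated chain carbon bound to an aromatic carbon and a saturated chain carbon. The three measured steps all swap one aromatic group on that same chain carbon for another, and none of them moved the number beyond the scatter: a 1.9-fold higher number from compound 1 to compound 2 (0.28 log units; within the scatter), a 1.8-fold higher number from compound 1 to compound 3 (0.26 log units; within the scatter) and a 1.0-fold lower number from compound 2 to compound 3 (0.02 log units; within the scatter). The change to compound 4 is larger in what enters than any of those, so a somewhat wider range is reasonable, but the measured steps give no reason to expect a shift in this assay beyond the scatter in either direction. Compound 4 is therefore expected to give about 65 nM, between 20 nM and 220 nM, an expected step of a 1.2-fold higher number from compound 2 to compound 4 (0.08 log units; within the scatter).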

Compound 4, half-maximal effective concentration: 398 nM
The estimate for compound 4 lay 6.1-fold (0.79 log units) below the measured number; the whole stated range lies below it.
By their numbers in this assay, from the lowest: compounds 1, 3 and 2 (each within the scatter of the next); then compound 4.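

In this assay, among these compounds, putting 1-benzyl-1H-imidazol-2-yl in place of phenyl gives a 7.4-fold higher number from compound 2 to compound 4 (0.87 log units; beyond the scatter), the first step at this position to lie beyond the scatter. The position therefore does respond to what it carries: exchanges among phenyl, 3,4-difluorophenyl and pyridin-2-yl could not be told apart, whereas this larger, two-ring group means that more compound is needed for the effect, although the step remains modest. Nothing available here explains the change.

The compounds shown leave open whether the higher number goes with the imidazole ring itself or with the benzyl group on it. A plain 1H-imidazol-2-yl or a 1-methyl-1H-imidazol-2-yl on the same chain carbon would separate these two possibilities.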